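The compounds below may be only part of what the source reports. "The series", "measured", "known", "first", "only" and "open" are said of these compounds alone.

In an ADME assay on L132 cells (Homo sapiens) for cytotoxicity, read by MTT assay, with a stated time of 72 h (on this read-out lower numbers stand for stronger inhibition and higher numbers for weaker inhibition), compound 3 `COc1cc(C2=C(c3ccc(OCC(=O)O)cc3)C(O)CC2=O)cc(OC)c1OC` gives "not determined" (no result reported), so it offers no number to start from. Compound 4 `CCOC(=O)COc1ccc(C2=C(c3cc(OC)c(OC)c(OC)c3)C(=O)CC2O)cc1` differs from it by ethyl in place of hydrogen on an oxygen next to a carbonyl group, which turns carboxymethyl into (ethoxycarbonyl)methyl. Compound 1 `COc1ccc(C2=C(c3cc(OC)c(OC)c(OC)c3)C(=O)C(OC(C)=O)C2)cc1F` gives < 1 ug/mL, a limit of the assay and not a number. Compound 2 `COc1ccc(C2=C(c3cc(OC)c(OC)c(OC)c3)C(=O)C(OC(C)=O)C2)cc1Cl` gives < 1 ug/mL, also a limit. Going by the values given here, the only measured step, a step that the two limits leave unreadable from compound 1 to compound 2, is chloro in place of fluoro on an aromatic carbon. That is a different change, so it suggests no size or direction for this one in this assay. The expectation therefore leans only on (the limit of < 1 ug/mL in this assay, at which 2 of the 3 values shown sit), where compound 1 and compound 2 sit. Compound 4 is estimated at 0.6 ug/mL, with an expected range of 0.1 ug/mL to 5 ug/mL.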

Compound 4, half-maximal inhibitory concentration: > 100 ug/mL
Compound 4: no number, only a limit; the forecaster's own chance of this, stated with the estimate: 65%; middle value at least 160-fold (2.22 log units) from the limit.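

No new step can be read between compound 3, which has no reported result, and compound 4, whose > 100 ug/mL is a limit of the assay and not a number. Going by these compounds, how far ethyl in place of hydrogen shifts the value in this assay stays open.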